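Acetamido replaces isopropoxy on the aryl ring

A few compounds are considered here, and "the series" means these few. Any claim that something is new, unique, unknown or untested is made for them only; others in the source may bear on it.

Two analogues sharing one core have been characterised so far. Compound 1 `O=C(Nc1nc(-c2cccc(F)c2)cs1)c1ccc([N+](=O)[O-])o1` gives 51600 nM in an ADME assay on Vero cells (Chlorocebus sabaeus) for cytotoxicity, read by MTT assay, with a stated time of 72 h; a higher number here means a weaker inhibitor, a lower number a stronger inhibitor. Compound 2 `CC(C)Oc1cccc(-c2csc(NC(=O)c3ccc([N+](=O)[O-])o3)n2)c1` gives 69500 nM in this assay. Among the compounds with values here, compound 2 therefore holds the highest of the two numbers, with compound 1 nearest to it; the only step between them, a 1.3-fold higher number from compound 1 to compound 2 (0.13 log units; within the scatter), lies within the scatter. Compound 3 `CC(=O)Nc1cccc(-c2csc(NC(=O)c3ccc([N+](=O)[O-])o3)n2)c1` carries a further change at the same aromatic carbon: acetamido in place of isopropoxy on an aromatic carbon. Within the data shown here, no step with an acetamido group has been measured, so the only guide is the exchange from compound 1 to compound 2, in which a change at this position left the number within the scatter. A step of similar size, with no clear direction, is expected here, namely a 1.2-fold lower number from compound 2 to compound 3 (0.06 log units; within the scatter). Compound 3 is estimated to give 60000 nM in this assay, within a range from 25000 nM to 150000 nM.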

Compound 3, half-maximal inhibitory concentration: 57600 nM
The estimate for compound 3 lay 1.0-fold (0.02 log units) above the measured number; the range from low to high includes it.
By their numbers in this assay, from the lowest: compounds 1, 3 and 2 (each within the scatter of the next).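

In this assay, acetamido, which carries a hydrogen-bond donor where isopropoxy carries none, gives a 1.2-fold lower number from compound 2 to compound 3 (0.08 log units; within the scatter), so this exchange adds a second step within the scatter at this aromatic carbon, meta to a large group. Against the fluoro group, acetamido gives a 1.1-fold higher number from compound 1 to compound 3 (0.05 log units; within the scatter), which places all three compounds within the scatter of one another, and the number in this series has so far not responded to any of these three groups at this position. No supporting data are available to account for this lack of response.

As far as these compounds go, it remains open whether an amine, a carboxylic acid or a longer chain at this carbon would also stay within the scatter. The compounds shown also leave open whether a change at another place on the shared core would move the number.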